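Replacing a nitro group with an amino group on compound 3

A few compounds are considered here, and "the series" means these few. Any claim that something is new, unique, unknown or untested is made for them only; others in the source may bear on it.

Measured compounds:
compound 1, `Nc1cc(OCc2ccccc2)nc(SCc2ccccc2)n1`, 53900 nM
compound 2, `CC(C)Cn1c(SCc2ccccc2)nc(N)cc1=O`, > 100000 nM
compound 3, `COc1cc(OC)n2cc(-c3ccc([N+](=O)[O-])cc3)nc2n1`, > 100000 nM

Of the compounds shown here, three have been tested in a functional assay on HT-29 cells (Homo sapiens) for antiproliferative activity, read by MTT assay, with a stated time of 72 h; a lower number here means a stronger inhibitor of growth, a higher number a weaker inhibitor of growth. Compound 1 gives 53900 nM. For compound 2 the result is only a limit, > 100000 nM. For compound 3 the result is likewise only a limit, > 100000 nM, so no number for its growth inhibition is known. Among the values shown, compound 3 stands at the limit of > 100000 nM in this assay, at which 2 of the 3 values shown sit, which means it can only be said to be a weak inhibitor of growth, not how weak.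

Compound 4, `COc1cc(OC)n2cc(-c3ccc(N)cc3)nc2n1`, has not yet been measured in this assay. It differs from compound 3 in one place: amino in place of nitro on an aromatic carbon.

Within the data shown here, no step between two measured compounds is known here, so the size of this change cannot be read from the data. Since compound 3 sits only at a limit, the expectation for compound 4 rests on that limit alone. Compound 4 is expected to remain a weak inhibitor of growth, with an estimated 100000 nM, in the range 30000 nM to 300000 nM. The step from compound 3 to compound 4 is thus estimated as a number no higher from compound 3 to compound 4 (the limit leaves the size open), which is not expected to exceed the usual scatter.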

Compound 4, concentration for 50% growth inhibition: > 100000 nM
Compound 4: no number, only a limit; the forecaster's own chance of this, stated with the estimate: 60%; the middle value lies on the limit itself.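

In this assay, no size can be read for the step between compound 3 and compound 4, because the results for both are only limits: the limit of > 100000 nM in this assay, at which 3 of the 4 values shown sit.

The compounds shown leave open how weakly compound 3 and compound 4 inhibit growth, and whether amino in place of nitro on an aromatic carbon makes any difference.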